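This account rests on a few compounds, and the source may have more. Where it says the series, first, only, none or still open, it means among the compounds named here.

Series notes. Compound 1 `COc1ccc2[nH]cc(C(=O)/C(C#N)=C/C=C(\Cl)c3ccc(OC)c(OC)c3)c2c1` is known in a functional assay on MCF7 cells (Homo sapiens) for cytotoxicity, read by sulforhodamine B assay, with a stated time of 48 h (on this read-out higher numbers stand for weaker inhibition of growth and lower numbers for stronger inhibition of growth), only as a limit, not as a number. In this assay compound 1 gives > 100000 nM, which is a limit of the assay. Compound 2 `COc1ccc(/C(Cl)=C/C=C(\C#N)C(=O)c2c[nH]c3ccc(OC)cc23)cc1` differs from compound 1 in one place, hydrogen in place of methoxy on an aromatic carbon. In this assay compound 2 gives > 100000 nM, again a limit and not a number. The step that the two limits leave unreadable from compound 1 to compound 2 cannot be read, as the limit of > 100000 nM in this assay, at which 2 of the 2 values shown sit, shows. Compound 3 `COc1ccc2[nH]cc(C(=O)/C(C#N)=C/C=C(\Cl)c3cc(OC)c(OC)c(OC)c3)c2c1` has not been measured; it differs from compound 1 by methoxy in place of hydrogen on an aromatic carbon. For the measured compounds named here, the only measured step, from compound 1 to compound 2, is the unreadable one, so no size of change is established on which to build, and the new methoxy has no measured counterpart here. Compound 3 is expected to sit at the same limit, the estimated step being a step that the limit leaves unreadable from compound 1 to compound 3, within the scatter. For compound 3 the estimate is 150000 nM, between 50000 nM and 500000 nM, most likely reported as a limit only.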

Compound 3, concentration for total growth inhibition: > 100000 nM
Compound 3: a limit, no number; the forecaster's own chance of this, stated with the estimate: 85%; the middle value does not contradict the limit.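

In this assay compound 3 gives > 100000 nM, a limit and not a number. For the compounds shown here, no step can therefore be read between compound 1 and compound 3, the reading being set by a shared limit: the limit of > 100000 nM in this assay, at which 3 of the 3 values shown sit. The compounds shown leave open what effect, if any, the methoxy or hydrogen changes have on growth inhibition in this assay.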